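From furan-2-yl to aminomethyl, one change in potency?

The source may hold more compounds than are shown below. What is called first, only, known or untested is meant among the compounds shown, and "the series" means these compounds.

In a functional assay (aorta) with Rattus norvegicus as the target (on this read-out lower numbers stand for stronger inhibition and higher numbers for weaker inhibition), compound 1 (`CCO/C(O)=C1\C(COCC(O)CO)=NC(C)=C(C(=O)OC)C1c1cccc(Cl)c1Cl`) gives 15.9 nM and compound 2 (`CCO/C(O)=C1\C(COCC(C)(O)c2ccco2)=NC(C)=C(C(=O)OC)C1c1cccc(Cl)c1Cl`) gives 15.9 nM so compound 2 stands level with compound 1. Compound 3 (`CCO/C(O)=C1\C(COCC(C)(O)CN)=NC(C)=C(C(=O)OC)C1c1cccc(Cl)c1Cl`) differs from compound 2 by one change (aminomethyl in place of furan-2-yl on a saturated chain carbon bound to an oxygen on a saturated carbon and two saturated chain carbons) on a saturated chain carbon bound to an oxygen on a saturated carbon and two saturated chain carbons. Among the compounds with values here, only one measured step bears on this (no change at the digits printed from compound 1 to compound 2 (within the scatter)) and it exchanged 1,2-dihydroxyethyl for 1-(furan-2-yl)-1-hydroxyethyl within the scatter. The expected step (a 1.0-fold higher number from compound 2 to compound 3 (0.00 log units; within the scatter)) in this assay is therefore none beyond the scatter, in neither direction. Compound 3 is estimated at 16 nM (expected range 5 nM to 50 nM).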

Compound 3, half-maximal inhibitory concentration: 158 nM
Estimate against measurement, compound 3: 9.9-fold (0.99 log units) below, outside the stated range (above it).
By their numbers in this assay, from the lowest: compounds 1 and 2 (each within the scatter of the next); then compound 3.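

This position does not tolerate every group: in this assay, aminomethyl in place of furan-2-yl gives a 9.9-fold higher number from compound 2 to compound 3 (1.00 log units; beyond the scatter), although the earlier exchange at this site stayed within the scatter. The same holds against the first side chain, as 1-(aminomethyl)-1-hydroxyethyl in place of 1,2-dihydroxyethyl gives a 9.9-fold higher number from compound 1 to compound 3 (1.00 log units; beyond the scatter). Nothing available explains this weaker inhibition. With only these compounds, the result cannot be assigned to the nitrogen or to the loss of the furan ring. A dimethylaminomethyl group or a phenyl ring at this position would leave the picture open to further testing.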